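The source may report more compounds than this note shows. Statements on the series, on what has been measured and on what is new or still open speak of the compounds shown alone.

In an assay on HEK293 cells for positive allosteric modulation of metabotropic glutamate receptor 5 (Homo sapiens), read by FLIPR, with a stated time of 1 h (a lower number here means that less compound is needed, a higher number that more compound is needed for the effect), compound 3 `CC1CCCC(C(=O)N2CCc3nc(C#Cc4ccccc4)sc3C2)C1` gives 100 nM, the lowest of the two numbers shown. Compound 2 `COC1CC(C(=O)N2CCc3nc(C#Cc4ccccc4)sc3C2)C1` gives 640 nM in this assay. For compound 1 `CC(=O)N1CCc2nc(C#Cc3ccccc3)sc2C1` this assay reports only a limit, > 10000 nM, which is the limit of > 10000 nM in this assay, at which 1 of the 3 values shown sits. On the carbonyl carbon, the 3-methoxycyclobutyl brings an at least 15-fold lower number from compound 1 to compound 2 (1.19 log units; beyond the scatter), the 3-methylcyclohexyl brings an at least 100-fold lower number from compound 1 to compound 3 (2.00 log units; beyond the scatter), and the exchange of one ring for the other brings a 6.4-fold lower number from compound 2 to compound 3 (0.81 log units; beyond the scatter).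

Compound 4 `O=C(C1CCOCC1)N1CCc2nc(C#Cc3ccccc3)sc2C1` differs from compound 3 in one place: oxan-4-yl in place of 3-methylcyclohexyl on a carbonyl carbon. The measured steps show that a six-membered ring of carbon only is rewarded over a smaller ring bearing a methoxy, and that any ring is rewarded over a bare methyl. Compound 4 keeps the ring size of compound 3 but loses the methyl and gains an oxygen in the ring, which sits between the two measured cases. The expected step is therefore a 4.5-fold higher number from compound 3 to compound 4 (0.65 log units; beyond the scatter), a moderate rise. Compound 4 is estimated at 450 nM, with a range from 150 nM to 1800 nM.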

Compound 4, half-maximal effective concentration: 290 nM
Compound 4: the middle estimate sits 1.6-fold (0.19 log units) above what was measured; measured number inside the range.
By their numbers in this assay, from the lowest: compound 3; then compound 4; then compound 2. At a limit, above all of these: compound 1.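

On the carbonyl carbon, oxan-4-yl shows that a ring oxygen can stand in a six-membered ring and keep most of what the 3-methylcyclohexyl gives in this assay: it brings a 2.9-fold higher number from compound 3 to compound 4 (0.46 log units; beyond the scatter), yet still a 2.2-fold lower number from compound 2 to compound 4 (0.34 log units; beyond the scatter), both modest steps. The six-membered ring thus stays ahead of the 3-methoxycyclobutyl even with the oxygen in it and the methyl gone. Against the bare methyl it brings an at least 34-fold lower number from compound 1 to compound 4 (1.53 log units; beyond the scatter), a large step that is measured from a limit and not from a number, and compound 1 stands at that limit: the limit of > 10000 nM in this assay, at which 1 of the 4 values shown sits.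

The compounds shown leave open whether the rise with oxan-4-yl belongs to the ring oxygen or to the lost methyl, which plain cyclohexyl would separate. Going by these compounds, how a ring amine such as piperidin-4-yl or an open chain such as pentyl would fare on this carbonyl carbon also stays open.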